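Propyl for isopropyl on the amine of compound 2

The source may hold more compounds than are shown below. What is called first, only, known or untested is meant among the compounds shown, and "the series" means these compounds.

In an ADME assay on HEK293 cells (Homo sapiens) for cytotoxicity, read by CellTiter-Glo and resazurin assay, with a stated time of 72 h (a higher number here means that more compound is needed for the effect, a lower number that less compound is needed), compound 1 (`CCCN(Cc1ccc(OCCCCCC(=O)OCC)cc1)C(=O)c1ccc(Br)cc1`) gives (> 26000 nM), which is a limit of the assay and not a number. Compound 2 (`CCOC(=O)CCCCCOc1ccc(CNC(C)C)cc1`) gives (> 26000 nM), which is also a limit and not a number. Going by the values given here, neither compound has a measured number, so the series so far consists of (the limit of > 26000 nM in this assay, at which 2 of the 2 values shown sit). Compound 3 (`CCCNCc1ccc(OCCCCCC(=O)OCC)cc1`) has the same atoms as compound 2, joined differently, with propyl in place of isopropyl on an amine nitrogen. Among the compounds with values here, no step between measured compounds is available in this assay. The step (a number no higher from compound 2 to compound 3 (the limit leaves the size open)) is expected to be none beyond the scatter, in either direction, and this expectation rests only on the limit of compound 2 (> 26000 nM). For compound 3 the estimated value is (26000 nM), with an expected range from (14000 nM) to (40000 nM).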

Compound 3, half-maximal effective concentration: > 26000 nM
Compound 3 was reported as a limit; the forecaster's own chance of this, stated with the estimate: 80%; the middle value lies on the limit itself.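

The results for compound 1, compound 2 and compound 3 are all limits of the assay and not numbers, so the steps to compound 3 from compound 1 and from compound 2 cannot be read. The compounds shown leave open whether their cytotoxicity differs at all.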